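This account rests on a few compounds, and the source may have more. Where it says the series, first, only, none or still open, it means among the compounds named here.

Compound 1 `O=C(/C=C/c1ccc(NC(=O)Nc2ccc(Cl)c(C(F)(F)F)c2)cc1)NC1CCC1` gives 15400 nM in a functional assay on A-375 cells (Homo sapiens) for inhibition, read by MTT assay, with a stated time of 120 h; a lower number here means a stronger inhibitor, a higher number a weaker inhibitor.
Compound 2 `CC(NC(=O)c1cccc(-c2ccc(NC(=O)Nc3ccc(Cl)c(C(F)(F)F)c3)cc2)c1)c1ccccc1` gives 5170 nM in this assay.
Compound 3 `CC(NC(=O)/C=C/c1ccc(NC(=O)Nc2ccc(Cl)c(C(F)(F)F)c2)cc1)c1ccccc1` gives 20800 nM in this assay.

Among these three, compound 3 has the highest number. Its nearest neighbour is compound 1, and the step of a 1.4-fold higher number from compound 1 to compound 3 (0.13 log units; within the scatter) lies within the scatter, so the two cannot be placed in order. Compound 2 sits further off, with a number that is lower by an amount beyond the scatter.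

Compound 4 `CNC(=O)/C=C/c1ccc(NC(=O)Nc2ccc(Cl)c(C(F)(F)F)c2)cc1` has not yet been measured. It differs from compound 3 in one place: methyl in place of 1-phenylethyl on an amide-type nitrogen. Among the compounds with values here, the only measured step that bears on this position is a 1.4-fold higher number from compound 1 to compound 3 (0.13 log units; within the scatter), where one group on the amide-type nitrogen was exchanged for another without a change beyond the scatter. Within the data shown here, that step suggests this position tolerates change, though no measured compound carries a group as small as methyl there, so some uncertainty remains. The expectation for compound 4 is therefore a step of a 1.1-fold higher number from compound 3 to compound 4 (0.02 log units; within the scatter), roughly no change beyond the scatter. Compound 4 is estimated at 22000 nM, with a range from 9000 nM to 55000 nM.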

Compound 4, half-maximal inhibitory concentration: 20900 nM
The estimate for compound 4 lay 1.1-fold (0.02 log units) above the measured number; measured number inside the range.
By their numbers in this assay, from the lowest: compound 2; then compounds 1, 3 and 4 (each within the scatter of the next).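

Replacing the whole 1-phenylethyl group, aromatic ring included, with a methyl on the amide-type nitrogen gives a 1.0-fold higher number from compound 3 to compound 4 (0.00 log units; within the scatter) in this assay, so that ring makes no difference this read-out can detect. Methyl in place of cyclobutyl gives a 1.4-fold higher number from compound 1 to compound 4 (0.13 log units; within the scatter), which extends the tolerance seen earlier between two larger groups down to a single carbon, and compounds 1, 3 and 4 cannot be placed in order. Nothing measured here offers an explanation for this flat result.

As far as these compounds go, all three groups on this nitrogen contain only carbon, so it remains open whether an amine or a carboxylic acid on a longer chain would shift the number. From the compounds shown here alone, a second methyl on that nitrogen, or no carbon group there at all, is equally open.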